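Swapping (4-methylphenyl)amino for 4-methylpiperazin-1-yl

The source may hold more compounds than are shown below. What is called first, only, known or untested is meant among the compounds shown, and "the series" means these compounds.

- compound 1 `CCC(C)n1cnc2c(NCc3ccc(C(=O)Nc4ccccc4N)cc3)nc(Cl)nc21` gives 3030 nM
- compound 2 `Cc1ccc(Nc2nc(Cl)nc3c2ncn3Cc2ccc(C(=O)Nc3ccccc3N)cc2)cc1` gives 1050 nM

Both values come from a functional assay on HeLa cells (Homo sapiens) for antiproliferative activity, read by CCK-8 assay, with a stated time of 72 h; on this read-out lower numbers stand for stronger inhibition and higher numbers for weaker inhibition. Compound 2 holds the lower number of the two, and the gap up to compound 1 lies beyond the usual scatter. Compound 3 `CN1CCN(c2nc(Cl)nc3c2ncn3Cc2ccc(C(=O)Nc3ccccc3N)cc2)CC1` has not yet been measured. It carries 4-methylpiperazin-1-yl in place of (4-methylphenyl)amino on an aromatic carbon of the shared core (4-methylpiperazin-1-yl in place of (4-methylphenyl)amino on an aromatic carbon). Among the measured compounds shown here, no measured pair shows this change on its own, so the data offer only a rough guide. A modest rise in the number is expected in this assay, similar in size to the gap between the two measured compounds, with compound 1 at 3030 nM. The expected change is a step of a 2.4-fold higher number from compound 2 to compound 3 (0.38 log units; beyond the scatter). Compound 3 is estimated at 2500 nM, with an expected range of 800 nM to 8000 nM.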

Compound 3, half-maximal inhibitory concentration: 1170 nM
Estimate against measurement, compound 3: 2.1-fold (0.33 log units) above, and the stated range covers the measured number.
By their numbers in this assay, from the lowest: compounds 2 and 3 (each within the scatter of the next); then compound 1.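

Putting 4-methylpiperazin-1-yl in place of (4-methylphenyl)amino on this aromatic carbon of the shared core gives a 1.1-fold higher number from compound 2 to compound 3 (0.05 log units; within the scatter) in this assay. The position therefore holds a non-aromatic ring with 2 hetero atoms, carrying 0 hydrogen-bond donors, with a read-out that stays within the scatter of the one given by a carbon-only aromatic ring on an amino link with 1 hydrogen-bond donor. This rests on a single pair, and no measurement at hand explains why the two groups read alike.

Going by these compounds, what remains open is whether a morpholine ring or a small open-chain amine such as dimethylamino would also stay within the scatter at this carbon. Also open, on these data alone, is how the number would respond if an amine replaced the chloro group on the same ring.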